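The source may report more compounds than this note shows. Statements on the series, on what has been measured and on what is new or still open speak of the compounds shown alone.

In a functional assay on MCF7 cells (Homo sapiens) for antiproliferative activity, read by MTT assay, with a stated time of 72 h (a higher number here means a weaker inhibitor, a lower number a stronger inhibitor), compound 1 `CC1=CC[C@H]2[C@H](CC[C@]2(C)O)C(C)(C)[C@@H]1CC[C@H]1[C@]2(C)CC[C@H](OC(=O)c3ccccc3)C(C)(C)O[C@H]2CC[C@@]1(C)O` gives 21000 nM. Compound 3 `CC1=CC[C@H]2[C@H](CC[C@]2(C)O)C(C)(C)[C@@H]1CC[C@H]1[C@]2(C)CC/C(=N/OC(=O)c3ccccc3)C(C)(C)O[C@H]2CC[C@@]1(C)O` gives 25600 nM, and these two numbers, the only exact ones available, lie within the scatter of each other. Compound 2 `CC1=CC[C@H]2[C@@H]1CC=C(C)[C@@H](CC[C@H]1[C@]3(C)CC[C@H](OC(=O)c4ccncc4)C(C)(C)O[C@H]3CC[C@@]1(C)O)C2(C)C` reads > 50000 nM, which is a limit of the assay and not a number. Compound 4 `CC1=CC[C@H]2[C@H](CC[C@]2(C)O)C(C)(C)[C@@H]1CC[C@H]1[C@]2(C)CC[C@H](OC(=O)c3ccc([N+](=O)[O-])cc3)C(C)(C)O[C@H]2CC[C@@]1(C)O` keeps the core of compound 1 and differs from it by nitro in place of hydrogen on an aromatic carbon, with nitro in place of hydrogen on an aromatic carbon, para to a large group. Going by the values given here, no measured pair shows this change, so the expectation rests on compound 1 at 21000 nM. In this assay, the expected change is none beyond the scatter, namely a 1.2-fold lower number from compound 1 to compound 4 (0.07 log units; within the scatter). Compound 4 is estimated at 18000 nM, with an expected range of 7000 nM to 45000 nM.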

Compound 4, half-maximal inhibitory concentration: 21600 nM
Estimate against measurement, compound 4: 1.2-fold (0.08 log units) below; low and high end bracket the measured number.
By their numbers in this assay, from the lowest: compounds 1, 4 and 3 (each within the scatter of the next). At a limit, above all of these: compound 2.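

In this assay, phenyl to 4-nitrophenyl on the benzoyloxy group leaves the number unmoved, with a 1.0-fold higher number from compound 1 to compound 4 (0.01 log units; within the scatter) across this change. Nitro is therefore tolerated at this place on the aromatic ring, which the earlier compounds could not show, since none of them carried a group on that ring. No measurement shown accounts for this flat step. As far as these compounds go, whether an amine or a carboxylic acid in the same place would shift the number remains open. So does the effect of nitro on the ring of compound 3.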